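Triazole tail swap on the furanone series: compound 3 outlook

The compounds below may be only part of what the source reports. "The series", "measured", "known", "first", "only" and "open" are said of these compounds alone.

Measured so far:
compound 1 `O=C1O/C(=C\Cn2cc(-c3cc(F)cc(F)c3)nn2)C(OCc2ccccc2)=C1OCc1ccccc1` — > 100000 nM
compound 2 `O=C1O[C@H]([C@@H](O)Cn2cc(CNS(=O)(=O)c3ccc(F)cc3)nn2)C(OCc2ccccc2)=C1OCc1ccccc1` — 22900 nM

For the measured compounds named here, in a functional assay on HCT-116 cells (Homo sapiens) for antiproliferative activity, read by MTT assay, with a stated time of 72 h (on this read-out lower numbers stand for stronger inhibition and higher numbers for weaker inhibition), compound 2 gives 22900 nM and stands at the only actual number in this set. Compound 1 gives > 100000 nM, which is a limit of the assay rather than a number; (the limit of > 100000 nM in this assay, at which 1 of the 2 values shown sits).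

Compound 3 `O=C1O[C@H]([C@@H](O)Cn2cc(-c3cc(F)cc(F)c3)nn2)C(OCc2ccccc2)=C1OCc1ccccc1` differs from compound 2 in one place: 3,5-difluorophenyl in place of (((4-fluorophenyl)sulfonyl)amino)methyl on an aromatic carbon. Going by the values given here, no measured step covers this change, so the expected size of the step rests only on these two compounds. Compound 3 is expected to weaken, with the step from compound 2 being a 2.0-fold higher number from compound 2 to compound 3 (0.29 log units; within the scatter), beyond the scatter. Compound 3 is accordingly estimated at 45000 nM, within 12000 nM to 150000 nM, with a real chance that only a limit is reported.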

Compound 3, half-maximal inhibitory concentration: 48200 nM
Beside the measured number, compound 3's estimate is 1.1-fold (0.03 log units) below it, within the range that was stated.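

In this assay, replacing (((4-fluorophenyl)sulfonyl)amino)methyl with 3,5-difluorophenyl on this aromatic carbon gives a 2.1-fold higher number from compound 2 to compound 3 (0.32 log units; beyond the scatter), a modest weakening. This position therefore keeps a measurable response even when the entering group has no hydrogen-bond donors or acceptors. Compound 1, which carries the same 3,5-difluorophenyl, stays at a limit of the assay: the limit of > 100000 nM in this assay, at which 1 of the 3 values shown sits.

Going by these compounds, the two tails differ in several features at once, so the part of the leaving group behind the step stays open. On these data alone, how an amine or a carboxylic acid on this carbon would read also remains open.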